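Swapping chloro for methoxy on the thiazole aryl of compound 1

A few compounds are considered here, and "the series" means these few. Any claim that something is new, unique, unknown or untested is made for them only; others in the source may bear on it.

Going by the values given here, compound 1 `Cc1nc(-c2ccc(Cl)cc2)sc1C(=O)CSc1nc(N)c(C#N)c(-c2ccc(Cl)cc2)n1` is the strongest of the three compounds measured so far in a functional assay on U-87MG ATCC cells for antiproliferative activity against U-87 MG (Homo sapiens), read by MTT assay, with a stated time of 48 h (a lower number here means a stronger inhibitor, a higher number a weaker inhibitor), where compound 1 gives 3420 nM. The two others sit well behind it. Compound 2 `COc1ccc(-c2nc(C)c(C(=O)CSc3nc(-c4ccc(OC)cc4)c(C#N)c(=O)[nH]3)s2)cc1` gives 25300 nM in this assay, a gap to compound 1 that is beyond the scatter, and compound 3 `COc1cccc(-c2nc(SCC(=O)c3sc(-c4ccc(Cl)cc4)nc3C)[nH]c(=O)c2C#N)c1` gives 41000 nM, the furthest of the three from compound 1. Neither of those two differs from compound 1 in a single place, so what divides them from it cannot be assigned to one change.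

Compound 4 `COc1ccc(-c2nc(C)c(C(=O)CSc3nc(N)c(C#N)c(-c4ccc(Cl)cc4)n3)s2)cc1` has not yet been measured. It is compound 1 with one alteration: methoxy in place of chloro on an aromatic carbon. Among the compounds with values here, no measured pair shows this exact step, so any expectation rests on compound 1 alone and on the general picture that the methoxy-bearing compounds 2 and 3 gave the higher numbers.

On that basis the step is expected to be small and, if anything, toward a weaker inhibitor, with a 1.6-fold higher number from compound 1 to compound 4 (0.21 log units; within the scatter) as the estimated shift in this assay. Compound 4 is therefore expected to give about 5500 nM, within a range from 1500 nM to 20000 nM.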

Compound 4, half-maximal inhibitory concentration: 4540 nM
The estimate for compound 4 lay 1.2-fold (0.08 log units) above the measured number; the range from low to high includes it.
By their numbers in this assay, from the lowest: compounds 1 and 4 (each within the scatter of the next); then compounds 2 and 3 (each within the scatter of the next).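

In this assay, methoxy in place of chloro gives a 1.3-fold higher number from compound 1 to compound 4 (0.12 log units; within the scatter), so the 4-chlorophenyl to 4-methoxyphenyl change, on an aromatic carbon para to a large group, leaves a difference that cannot be told from the scatter. Going by these compounds alone, this is the first single-place step, and it offers no support for the earlier general picture that links methoxy with higher numbers: this one change does not reproduce a gap of the size seen for compounds 2 and 3, which differ from compound 1 in more than one place. No measurement at hand bears on why the two groups give results so close together.

From the compounds shown here alone, whether a hydroxyl, an amine or a carboxylic acid in the same place would also stay within the scatter remains open, as does whether the same swap would be as small on the other 4-chlorophenyl of compound 1. Which of the several differences separates compounds 2 and 3 from compound 1 also remains unassigned.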